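Nitrophenyl isomers on the sulfonyl sulfur

A few compounds are considered here, and "the series" means these few. Any claim that something is new, unique, unknown or untested is made for them only; others in the source may bear on it.

In an ADME assay on HEK-293T cells (Homo sapiens) for inhibition, read by CCK-8 assay, with a stated time of 48 h, tested at 20 uM (a higher number here means more inhibition of growth at the concentration tested, a lower number less inhibition of growth), compound 2 `COc1ccc(Cc2nnc(NC(=O)/C(C#N)=C/c3ccccc3OS(=O)(=O)c3ccc([N+](=O)[O-])cc3)s2)cc1` gives 17%. Among the measured compounds shown here, the only other measured compound, compound 1 `COc1ccc(Cc2nnc(NC(=O)/C(C#N)=C/c3ccccc3OS(=O)(=O)c3ccc(C)cc3)s2)cc1`, gives 21%, so the two lie within the scatter of each other and neither can be ranked. The next compound is compound 3 `COc1ccc(Cc2nnc(NC(=O)/C(C#N)=C/c3ccccc3OS(=O)(=O)c3ccccc3[N+](=O)[O-])s2)cc1`. The change is 2-nitrophenyl in place of 4-nitrophenyl on a sulfonyl sulfur, in short 2-nitrophenyl in place of 4-nitrophenyl on a sulfonyl sulfur. For the measured compounds named here, one measured step bears on it, and only indirectly: nitro in place of methyl on an aromatic carbon gave a number 4 percentage points lower from compound 1 to compound 2 (within the scatter). Going by the values given here, no measured step changes only where a group sits, so the data offer no direct precedent. A shift beyond the scatter in this assay is therefore not expected. The expected step is a number 1 percentage points higher from compound 2 to compound 3 (within the scatter). Compound 3 is estimated at 18%, with an expected range of 6% to 32%.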

Compound 3, percent growth inhibition at one concentration: 18%
Estimate against measurement, compound 3: no gap at the digits printed, and the stated range covers the measured number.
By their numbers in this assay, from the lowest: compounds 2, 3 and 1 (each within the scatter of the next).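

In this assay, among the compounds shown here, 2-nitrophenyl in place of 4-nitrophenyl on the sulfonyl sulfur gives a number 1 percentage points higher from compound 2 to compound 3 (within the scatter) and so provides the first measured change of where a group sits at this position, with no shift beyond the scatter. Against the methyl-bearing sulfonyl aryl group, 2-nitrophenyl gives a number 3 percentage points lower from compound 1 to compound 3 (within the scatter) and so also leaves the number within the scatter, which means that the three compounds cannot be ranked in this assay. Nothing available explains this result or links it to any property of these groups.

Still open, on these data alone, is whether an amine or a carboxylic acid on this aromatic ring would move the number beyond the scatter. The same question stands for a longer alkyl chain on the sulfonyl sulfur in place of the ring.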